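A Hydroxyethyl Group Replaces Phenyl on the Shared Core

This account rests on a few compounds, and the source may have more. Where it says the series, first, only, none or still open, it means among the compounds named here.

Of the compounds shown here, three built on one shared core have been tested in an ADME assay on PC-3 cells (Homo sapiens) for cytotoxicity, read by sulforhodamine B assay, with a stated time of 48 h, tested at 10 uM; on this read-out higher numbers stand for more inhibition at the one concentration tested (going by the name of the read-out) and lower numbers for less inhibition. Compound 1 `COc1nc2ccc(Br)cc2cc1C(c1ccccc1)n1cc(-c2ccc(Br)cc2)nn1` gives 7.43%, compound 2 `CCCCCCCc1cn(C(c2ccccc2)c2cc3cc(Br)ccc3nc2OC)nn1` gives 4.42%, and compound 3 `COc1nc2ccc(Br)cc2cc1C(c1ccccc1)n1cc(-c2ccccc2)nn1` gives 5.97%. The three numbers sit close together: a number 3 percentage points lower from compound 1 to compound 2 (within the scatter), a number 1.5 percentage points lower from compound 1 to compound 3 (within the scatter), and a number 1.6 percentage points higher from compound 2 to compound 3 (within the scatter). Compound 3 stands second highest of the three, with compound 1 nearest and compound 2 furthest, both within the scatter, so no order among them can be claimed.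

Compound 4 `COc1nc2ccc(Br)cc2cc1C(c1ccccc1)n1cc(CCO)nn1` differs from compound 3 in one place: 2-hydroxyethyl in place of phenyl on an aromatic carbon. The measured steps that touch this position are the exchange of 4-bromophenyl for heptyl, a number 3 percentage points lower from compound 1 to compound 2 (within the scatter), and of heptyl for phenyl, a number 1.6 percentage points higher from compound 2 to compound 3 (within the scatter). Neither moved the read-out beyond the scatter. For the measured compounds named here, no measured compound carries a 2-hydroxyethyl group, so that group itself is untested here. With every change at this carbon having stayed within the scatter, as a number 3 percentage points lower from compound 1 to compound 2 (within the scatter) and a number 1.6 percentage points higher from compound 2 to compound 3 (within the scatter) show, the step to compound 4 in this assay is expected to be small, with no direction beyond the scatter. The expected step is a number 0.5 percentage points lower from compound 3 to compound 4 (within the scatter). Compound 4 is therefore estimated at 5.5%, within a range from 0% to 13%.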

Compound 4, a percentage reported as inhibition, at one concentration (the size of the read-out at that concentration, not a potency): 15.5%
The estimate for compound 4 lay 10 percentage points below the measured number; measured number above the stated range.
By their numbers in this assay, from the lowest: compounds 2, 3, 1 and 4 (each within the scatter of the next, the first and the last beyond it).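

In this assay this carbon, on the five-membered aromatic ring with 3 nitrogen, now gives a step beyond the scatter, which none of the earlier exchanges there did: a number 11.1 percentage points higher from compound 2 to compound 4 (beyond the scatter) with hydroxy in place of pentyl on a saturated chain carbon, two bonds along the chain from an aromatic carbon. The exchanges of the two aryl groups stay inside the scatter, as a number 9.5 percentage points higher from compound 3 to compound 4 (within the scatter) and a number 8.1 percentage points higher from compound 1 to compound 4 (within the scatter) show, so compound 4 separates from compound 2 alone, and the change that can be read here is one between two chains, not one between a chain and a ring. Nothing available bears on why the number moved at this step.

The compounds shown leave open whether the step belongs to the hydroxy group or to the shorter chain, a question that a plain ethyl group at this carbon would settle. Also open, as far as these compounds go, is how a longer hydroxyalkyl chain, or an amine or a carboxylic acid at the end of the chain, would read in this assay at this position.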